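From a Carbamate to a Benzylic Tertiary Amine

The source may hold more compounds than are shown below. What is called first, only, known or untested is meant among the compounds shown, and "the series" means these compounds.

Compound 2 `CC(C)(C)OC(=O)NCC1(O)CCN(CCCc2c[nH]c3ccc(-n4cnnc4)cc23)CC1` stands highest of the three numbers in an assay on CHO cells with 5-hydroxytryptamine receptor 1B (Homo sapiens) as the target (a lower number here means a stronger inhibitor, a higher number a weaker inhibitor), where compound 2 gives 340 nM. In this assay compound 1 `CN(CC1CC1)CC1(O)CCN(CCCc2c[nH]c3ccc(-n4cnnc4)cc23)CC1` gives 27 nM and compound 3 `CC(=O)Nc1ccc(CNCC2(O)CCN(CCCc3c[nH]c4ccc(-n5cnnc5)cc34)CC2)cc1` gives 30 nM. Compound 4 `Cc1ccccc1CN(C)CC1(O)CCN(CCCc2c[nH]c3ccc(-n4cnnc4)cc23)CC1` differs from compound 2 at one place: methyl(2-methylbenzyl)amino in place of (tert-butoxycarbonyl)amino on a saturated chain carbon bound to a saturated ring carbon. Going by the values given here, two measured steps bear on this change. The step of an 11-fold lower number from compound 2 to compound 3 (1.05 log units; beyond the scatter) puts a benzyl group on the amine nitrogen in place of the tert-butoxycarbonyl, and the step of a 13-fold higher number from compound 1 to compound 2 (1.10 log units; beyond the scatter) runs the opposite way, from a tertiary amine to the carbamate. Both were large, so a large downward step in this assay is expected for compound 4. The expected step is an 11-fold lower number from compound 2 to compound 4 (1.05 log units; beyond the scatter). Compound 4 is estimated to give 30 nM, within a range of 12 nM to 80 nM.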

Compound 4, half-maximal inhibitory concentration: 89 nM
Compound 4: middle estimate off by 3.0-fold (0.47 log units), on the low side; measured number outside the range, above it.
By their numbers in this assay, from the lowest: compounds 1 and 3 (each within the scatter of the next); then compound 4; then compound 2.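

In this assay, the methyl(2-methylbenzyl)amino group recovers only part of what the tert-butoxycarbonyl group loses, a 3.8-fold lower number from compound 2 to compound 4 (0.58 log units; beyond the scatter). It also falls short of the other two amines, a 3.0-fold higher number from compound 3 to compound 4 (0.47 log units; beyond the scatter) and a 3.3-fold higher number from compound 1 to compound 4 (0.52 log units; beyond the scatter), so amines at this position are not interchangeable, although compound 1 and compound 3 stand within the scatter of each other. No available evidence accounts for this gap.

On these data alone, whether an unsubstituted benzyl on the same methylamino nitrogen would stand nearer compound 1 or compound 4 remains open.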